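From 3-chlorophenyl to 4-bromophenyl: a small expected step

The source may report more compounds than this note shows. Statements on the series, on what has been measured and on what is new or still open speak of the compounds shown alone.

Measured in a functional assay on NCI-H460 cells (Homo sapiens) for inhibition, read by MTT assay, with a stated time of 72 h; on this read-out higher numbers stand for weaker inhibition and lower numbers for stronger inhibition:
- compound 1 `COc1cc(NC(C)CCCNC(=O)Nc2cccc(F)c2)c2ncccc2c1`: 24000 nM
- compound 2 `COc1cc(NC(C)CCCNC(=O)Nc2cccc(Cl)c2)c2ncccc2c1`: 37000 nM

For the measured compounds named here, compound 2 holds the higher of only two numbers, but it cannot be separated from compound 1, since the gap between them lies within the scatter of repeated measurements. Compound 3 `COc1cc(NC(C)CCCNC(=O)Nc2ccc(Br)cc2)c2ncccc2c1` has no value yet. Its difference from compound 2 is 4-bromophenyl in place of 3-chlorophenyl on an amide-type nitrogen.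

Going by the values given here, the one measured step that bears on this is a swap of one halogen for another, chloro in place of fluoro, and it was small: a 1.5-fold higher number from compound 1 to compound 2 (0.19 log units; within the scatter). Neither measured compound carries a 4-bromophenyl group, so this guide is only partial. In this assay, the expected step is a 1.2-fold lower number from compound 2 to compound 3 (0.09 log units; within the scatter), which would be no change beyond the scatter. For compound 3 the estimate is 30000 nM, with an expected range of 12000 nM to 75000 nM.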

Compound 3, half-maximal inhibitory concentration: 30000 nM
The estimate for compound 3 equals the measured number at the digits printed; low and high end bracket the measured number.
By their numbers in this assay, from the lowest: compounds 1, 3 and 2 (each within the scatter of the next).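

Compounds 1 and 2 differed only in the halogen, whereas here the halogen and its place on the phenyl ring change together, as 4-bromophenyl stands in place of 3-chlorophenyl. Even this double change gives only a 1.2-fold lower number from compound 2 to compound 3 (0.09 log units; within the scatter) in this assay, and the comparison with 3-fluorophenyl reads the same, with a 1.3-fold higher number from compound 1 to compound 3 (0.10 log units; within the scatter) as the step. The three halogenated phenyl groups on this amide-type nitrogen therefore cannot be told apart in this test, and no outside evidence explains why.

The two changes in compound 3 cannot be separated, and a 4-chlorophenyl group would be needed to compare halogen place directly. On these data alone, whether an unsubstituted phenyl, a carboxylic acid or an amine on that ring would move the number beyond the scatter also remains open.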